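The source may hold more compounds than are shown below. What is called first, only, known or untested is meant among the compounds shown, and "the series" means these compounds.

Measured so far:
Compound 1, `COc1ccc(/C=N/NC(=O)Nc2ccc(Oc3ccnc(-c4nncn4CCN(C)C)c3)c(F)c2)c(OC)c1OC`: 3970 nM
Compound 2, `CN(C)CCn1cnnc1-c1cc(Oc2ccc(NC(=O)N/N=C/c3cccc(Cl)c3Cl)cc2F)ccn1`: 130 nM
Compound 3, `CN(C)CCn1cnnc1-c1cc(Oc2ccc(NC(=O)N/N=C/c3ccc(Cl)cc3)cc2F)ccn1`: 530 nM

In a functional assay on HT-29 cells (Homo sapiens) for cytotoxicity, read by MTT assay, with a stated time of 72 h (a lower number here means a stronger inhibitor, a higher number a weaker inhibitor), compound 3 stands second highest of the three numbers. Its nearest neighbour is compound 2, reached by a 4.1-fold higher number from compound 2 to compound 3 (0.61 log units; beyond the scatter); its furthest is compound 1, from which a 7.5-fold lower number from compound 1 to compound 3 (0.87 log units; beyond the scatter) leads to compound 3. Compound 4, `CN(C)CCn1cnnc1-c1cc(Oc2ccc(NC(=O)N/N=C/c3cccc(O)c3)cc2F)ccn1`, has not been measured. It differs from compound 3 in one place: 3-hydroxyphenyl in place of 4-chlorophenyl on a carbon with a double bond to nitrogen.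

For the measured compounds named here, no measured step swaps a chlorine for a hydroxyl on this ring, so the estimate rests on the two steps that touch the same ring. The step of a 7.5-fold lower number from compound 1 to compound 3 (0.87 log units; beyond the scatter) shows that an oxygen-bearing ring gives a higher number than a chlorine-bearing one, and a 4.1-fold higher number from compound 2 to compound 3 (0.61 log units; beyond the scatter) shows that the ring pattern matters at a modest scale. Compound 4 carries one oxygen on its ring, fewer than compound 1, so a step smaller than that from compound 1 is expected, but in the same direction: compound 4 is expected to give a modestly higher number in this assay, a 2.8-fold higher number from compound 3 to compound 4 (0.45 log units; beyond the scatter). Compound 4 is therefore estimated at 1500 nM, with a range from 400 nM to 6000 nM.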

Compound 4, half-maximal inhibitory concentration: 330 nM
Compound 4: middle estimate off by 4.5-fold (0.66 log units), on the high side; the whole stated range lies above it.
By their numbers in this assay, from the lowest: compound 2; then compounds 4 and 3 (each within the scatter of the next); then compound 1.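

Compound 4 shows that this ring, on a carbon with a double bond to nitrogen, needs no chlorine to hold the level of compound 3: in this assay, the change to 3-hydroxyphenyl gives a 1.6-fold lower number from compound 3 to compound 4 (0.21 log units; within the scatter), and that step lies within the scatter. An oxygen on the ring therefore does not by itself bring the high number seen with 2,3,4-trimethoxyphenyl, since 3-hydroxyphenyl in place of that group gives a 12-fold lower number from compound 1 to compound 4 (1.08 log units; beyond the scatter), nearly as large a gain as any step seen from compound 1. The 2,3-dichlorophenyl ring keeps the lowest number of the four, as 3-hydroxyphenyl in its place gives a 2.5-fold higher number from compound 2 to compound 4 (0.40 log units; beyond the scatter), so the two rings bearing a single substituent sit together, apart from both compound 2 and compound 1.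

The compounds shown leave open whether an amine or a carboxylic acid on this ring would stay at the level of compound 3 and compound 4 or move away from it. Nothing measured here beyond these cell numbers bears on why the ring changes give these results.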